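Naphthalenyl replacement at the acetal position: compound 4 outlook

This account rests on a few compounds, and the source may have more. Where it says the series, first, only, none or still open, it means among the compounds named here.

Measured so far in a functional assay for inhibition, with Homo sapiens as the target; a lower number here means tighter binding, a higher number weaker binding:
- compound 1 `O=C(O)CC/C=C\CC1COC(c2ccccc2Cl)OC1c1cccnc1` gives 759 nM
- compound 2 `N#Cc1ccccc1C1OCC(C/C=C\CCC(=O)O)C(c2cccnc2)O1` gives 245 nM
- compound 3 `O=C(O)CC/C=C\CC1COC(c2ccc(Cl)cc2Cl)OC1c1cccnc1` gives 891 nM

Compound 3 carries the highest of the three numbers. Against compound 1 the gap is a 1.2-fold higher number from compound 1 to compound 3 (0.07 log units; within the scatter), so the two are not separable on these data. Against compound 2 the gap is a 3.6-fold higher number from compound 2 to compound 3 (0.56 log units; beyond the scatter), a modest but real difference. For the measured compounds named here, the only other step in the set is a 3.1-fold lower number from compound 1 to compound 2 (0.49 log units; beyond the scatter), which runs the opposite way and is of similar size.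

Compound 4 `O=C(O)CC/C=C\CC1COC(c2cccc3ccccc23)OC1c1cccnc1` differs from compound 3 in one place: naphthalen-1-yl in place of 2,4-dichlorophenyl on a saturated ring carbon. Going by the values given here, none of the measured steps covers this kind of change. The chloro-for-hydrogen step, a 1.2-fold higher number from compound 1 to compound 3 (0.07 log units; within the scatter), is the only one that enlarges the substituent on the same aromatic ring, and it stays within the scatter; the cyano-for-chloro and 2,4-dichlorophenyl-for-2-cyanophenyl steps swap the group rather than extend it. Taken together, the expectation for this assay is a step of a 1.3-fold lower number from compound 3 to compound 4 (0.10 log units; within the scatter), i.e. nothing reliably beyond the scatter, with the range widened for the untested change.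

Compound 4 is therefore estimated at 700 nM, with a range from 250 nM to 2000 nM.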

Compound 4, dissociation constant: 631 nM
Estimate against measurement, compound 4: 1.1-fold (0.05 log units) above; measured number inside the range.
By their numbers in this assay, from the lowest: compound 2; then compounds 4, 1 and 3 (each within the scatter of the next).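

Readings in this assay show that the saturated ring carbon between two ring oxygen atoms can carry naphthalen-1-yl, with its 2 six-membered aromatic rings of carbon only, in place of 2,4-dichlorophenyl without a separable change (a 1.4-fold lower number from compound 3 to compound 4 (0.15 log units; within the scatter)). For the compounds shown here, the same holds against the 2-chlorophenyl group (a 1.2-fold lower number from compound 1 to compound 4 (0.08 log units; within the scatter)), so compounds 1, 3 and 4 form one group on these numbers despite the added ring and the loss of chlorine, while 2-cyanophenyl remains the only group here with a separable gap to each of the others, including the new one (a 2.6-fold higher number from compound 2 to compound 4 (0.41 log units; beyond the scatter)). Nothing on hand accounts for the position of compound 2 relative to the other three.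

Still open, from the compounds shown here alone, is whether a nitrile placed on naphthalen-1-yl would bring the same step as it does on the phenyl ring, and whether a saturated cyclohexyl group or an aminophenyl group at this carbon would stay with compounds 1, 3 and 4. Going by these compounds, the pyridin-3-yl group and the 5-carboxypent-2-en-1-yl chain are also constant across all four compounds, so the effect of a shorter chain, or of an amide in place of the carboxylic acid, remains unknown.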